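Anilide replacement in a weakly active triazole series

The compounds below may be only part of what the source reports. "The series", "measured", "known", "first", "only" and "open" are said of these compounds alone.

Measured so far in an assay on isolated protein (Mus musculus) for inhibition of IL15-IL15 receptor (Homo sapiens), read by resazurin assay, with stated times of 30 min and 2.5 days; on this read-out higher numbers stand for weaker inhibition and lower numbers for stronger inhibition:
- compound 1 `Cn1c(Cc2nn(C)c(=O)c3ccccc23)nnc1SCC(=O)Nc1ccc(O)cc1`: "not active" (no number reported)
- compound 2 `Cn1c(Cc2nn(C)c(=O)c3ccccc23)nnc1SCCCCCCCC(=O)Nc1ccc(O)cc1`: > 30000 nM
- compound 3 `Cn1c(Cc2nn(C)c(=O)c3ccccc23)nnc1SCCCCCCCC(=O)Nc1ccccc1O`: 27000 nM

Compound 1 stands at the weak end of this small set: in this assay compound 1 is recorded as "not active" (no number reported), with no number attached. For compound 2 the value > 30000 nM is a limit of the assay and not a number. Compound 3 gives 27000 nM in this assay. Among the measured compounds shown here, the single step between measured compounds, an at least 1.1-fold lower number from compound 2 to compound 3 (0.04 log units; that floor lies within the scatter), has a floor that lies within the scatter, so compounds 2 and 3 cannot be told apart. The whole picture is summed up by the limit of > 30000 nM in this assay, at which 1 of the 3 values shown sits.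

Compound 4 `Cn1c(Cc2nn(C)c(=O)c3ccccc23)nnc1SCC(=O)Nc1ccc(F)cc1F` differs from compound 1 by 2,4-difluorophenyl in place of 4-hydroxyphenyl on an amide-type nitrogen. For the measured compounds named here, no measured step touches this change: the one step in hand concerns the hydroxyl position on the longer chain and says nothing about swapping the hydroxyl for two fluorines. Going by the values given here, with compound 1 recorded as "not active" (no number reported) and no measured compound reaching potency, compound 4 is expected to remain weak. Compound 4 is estimated at 40000 nM, with a range from 12000 nM to 150000 nM.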

Compound 4, half-maximal inhibitory concentration: "not active" (no number reported)
For compound 4 the study gives words and no number; no gap can be computed for the estimate.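

Compound 1 and compound 4 are both recorded in words only in this assay, so no new step can be read between them. The compounds shown leave open whether 2,4-difluorophenyl and 4-hydroxyphenyl differ at all on this amide-type nitrogen, and the set still rests on a limit: the limit of > 30000 nM in this assay, at which 1 of the 4 values shown sits.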